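From 2-methoxyethyl to 3-hydroxypropyl on the shared core

A few compounds are considered here, and "the series" means these few. Any claim that something is new, unique, unknown or untested is made for them only; others in the source may bear on it.

Measured in a functional assay on HT-29 cells (Homo sapiens) for inhibition, read by luminescence and CellTiter-Glo, with a stated time of 24 h; on this read-out lower numbers stand for an effect already at smaller amounts and higher numbers for an effect only at larger amounts of compound:
Compound 1 `CCn1nc(C(=O)N[C@H]2COc3ccccc3N(C)C2=S)nc1Cc1ccccc1`: 17 nM
Compound 2 `COCCn1nc(C(=O)N[C@H]2COc3ccccc3N(C)C2=S)nc1Cc1ccccc1`: 566 nM

Of the two, compound 2 stands highest at 566 nM, well beyond the scatter from compound 1. Compound 3 `CN1C(=S)[C@@H](NC(=O)c2nc(Cc3ccccc3)n(CCCO)n2)COc2ccccc21` carries the same atoms joined differently: hydroxymethyl in place of methoxy on a saturated chain carbon, two bonds along the chain from an aromatic nitrogen. This turns 2-methoxyethyl into 3-hydroxypropyl. Within the data shown here, one measured step bears on it, a 33-fold higher number from compound 1 to compound 2 (1.52 log units; beyond the scatter), a large change at the same place on the chain. Among the measured compounds shown here, that step compares a chain with and without methoxy, however, and no measured compound carries hydroxymethyl there. Compound 3, like compound 2, keeps an oxygen on a chain longer than ethyl, so no step beyond the scatter is expected in this assay. The estimated step is a 1.3-fold lower number from compound 2 to compound 3 (0.10 log units; within the scatter). For compound 3 the expected value is 450 nM, with an estimated range from 90 nM to 2200 nM.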

Compound 3, half-maximal effective concentration: 209 nM
Beside the measured number, compound 3's estimate is 2.2-fold (0.33 log units) above it, within the range that was stated.
By their numbers in this assay, from the lowest: compound 1; then compound 3; then compound 2.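

In this assay, the two chains of the same atoms are not equivalent at this position: moving from 2-methoxyethyl to 3-hydroxypropyl gives a 2.7-fold lower number from compound 2 to compound 3 (0.43 log units; beyond the scatter). The earlier compounds shown here showed only that adding methoxy to the chain carried a large penalty, whereas this result shows that the size of that penalty depends on how the oxygen is placed and capped. The gain is only partial, however, as the comparison with the ethyl chain still gives a 12-fold higher number from compound 1 to compound 3 (1.09 log units; beyond the scatter).

The change alters the end group and the chain together, so the compounds shown cannot separate the free hydroxyl from the longer chain, and a 2-hydroxyethyl chain, an amine or a carboxylic acid at this position would test this further. No measured evidence is available to explain the differences among these chains.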